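The compounds below may be only part of what the source reports. "The series", "measured", "known", "first", "only" and "open" are said of these compounds alone.

Measured in a functional assay on HCC827 cells (Homo sapiens) for antiproliferative activity, read by MTT assay, with a stated time of 72 h; a lower number here means a stronger inhibitor, a higher number a weaker inhibitor:
- Compound 1 `CC(C)n1c(Sc2ccccc2)nc2cnc(Nc3ccc(N4CCN(C)CC4)cc3)nc21`: 290 nM
- Compound 2 `CN1CCN(c2ccc(Nc3ncc4nc([S+]([O-])c5ccccc5)n([C@H]5CC[C@H](O)CC5)c4n3)cc2)CC1`: 268 nM
- Compound 3 `CC(C)n1c([S+]([O-])c2ccccc2)nc2cnc(Nc3ccc(N4CCN(C)CC4)cc3)nc21`: 215 nM

These three numbers all lie within the usual scatter of one another, so compound 1 cannot be ranked against the other two. It is simply one of a tight group.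

Compound 4 `CN1CCN(c2ccc(Nc3ncc4nc(Sc5ccccc5)n(CC5CC5)c4n3)cc2)CC1` has not yet been measured. Its difference from compound 1 is a single swap, cyclopropylmethyl in place of isopropyl on an aromatic nitrogen.

Two measured steps offer some guidance. For the measured compounds named here, only one of them changes the group on that same nitrogen: putting isopropyl in place of 4-hydroxycyclohexyl gives a 1.2-fold lower number from compound 2 to compound 3 (0.10 log units; within the scatter). Even this swap between two quite different groups stays within the scatter. The other step changes the phenylsulfanyl group instead and gives a 1.3-fold lower number from compound 1 to compound 3 (0.13 log units; within the scatter), also within the scatter.

Going by the values given here, no measured compound carries cyclopropylmethyl, so this is an extrapolation, and the range has to stay fairly wide. Still, no shift beyond the scatter is expected in this assay.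

The estimated change is a 1.0-fold lower number from compound 1 to compound 4 (0.02 log units; within the scatter).

For compound 4 the expected value is 280 nM, with an estimated range of 130 nM to 600 nM.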

Compound 4, half-maximal inhibitory concentration: 660 nM
The estimate for compound 4 lay 2.4-fold (0.37 log units) below the measured number; measured number outside the range, above it.
By their numbers in this assay, from the lowest: compounds 3, 2 and 1 (each within the scatter of the next); then compound 4.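

In this assay, the nitrogen carrying isopropyl in compound 1 proves sensitive to its group: cyclopropylmethyl gives a 2.3-fold higher number from compound 1 to compound 4 (0.36 log units; beyond the scatter), a modest change, but the first at this position to go beyond the scatter. For the compounds shown here, the only earlier swap on this nitrogen, a 1.2-fold lower number from compound 2 to compound 3 (0.10 log units; within the scatter), stayed within the scatter, but it was seen in compounds with an oxygen on the sulfur, whereas compounds 1 and 4 have a plain phenylsulfanyl group, so the two steps do not share a background. The new step swaps isopropyl for cyclopropylmethyl, a group that contains a three-membered ring, and nothing available explains why this costs activity.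

Going by these compounds alone, the single step cannot separate the effect of the ring from that of the extra carbon, so an n-propyl or n-butyl chain, or a cyclopropyl or cyclobutyl ring placed directly on the nitrogen, would be needed to tell them apart. Going by these compounds, it also remains open whether cyclopropylmethyl would give a similar step alongside the oxygen-bearing sulfur group of compound 3.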